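The source may hold more compounds than are shown below. What is called first, only, known or untested is meant among the compounds shown, and "the series" means these compounds.

Of the compounds shown here, three sharing one core have been tested in a functional assay on HEK293 cells for antagonist activity at transient receptor potential cation channel subfamily V member 1 (Homo sapiens), read by calcium flux; a lower number here means a stronger inhibitor, a higher number a weaker inhibitor. Compound 1 `FC(F)(F)c1ccc(Nc2ncnc3sc(Nc4c(Cl)cccc4Cl)nc23)cc1` gives 12 nM in this assay. Compound 2 `Cc1ccc(Nc2ncnc3sc(Nc4c(Cl)cccc4Cl)nc23)cc1` gives 33 nM in this assay, and the change of methyl in place of trifluoromethyl on an aromatic carbon gave a 2.8-fold higher number from compound 1 to compound 2 (0.44 log units; beyond the scatter). As far as these compounds go, compound 3 `NS(=O)(=O)c1ccc(Nc2ncnc3sc(Nc4c(Cl)cccc4Cl)nc23)cc1` reaches only the limit of this assay, > 5000 nM, so its true value is unknown. Both steps into it, an at least 410-fold higher number from compound 1 to compound 3 (2.61 log units; beyond the scatter) and an at least 150-fold higher number from compound 2 to compound 3 (2.18 log units; beyond the scatter), were large losses. Compound 4 `O=S(=O)(c1ccc(Nc2ncnc3sc(Nc4c(Cl)cccc4Cl)nc23)cc1)N1CCCC1` differs from compound 3 by pyrrolidin-1-yl in place of amino on a sulfonyl sulfur. Among the compounds with values here, no measured step compares two groups on a sulfonyl sulfur, so only the large losses into compound 3 bear here. For compound 4 the expected step is an at least 1.6-fold lower number from compound 3 to compound 4 (0.22 log units; that floor lies within the scatter). Compound 4 is therefore estimated at 3000 nM, between 600 nM and 15000 nM.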

Compound 4, half-maximal inhibitory concentration: 1 nM
For compound 4 the middle estimate is 3000-fold (3.48 log units) above the measured one, outside the stated range (below it).
By their numbers in this assay, from the lowest: compound 4; then compound 1; then compound 2. At a limit, above all of these: compound 3.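

A sulfonyl group on this aromatic carbon need not cost activity: what sits on the sulfonyl sulfur decides the outcome, with an at least 5000-fold lower number from compound 3 to compound 4 (3.69 log units; beyond the scatter). That step starts from a limit and not from a true number: the limit of > 5000 nM in this assay, at which 1 of the 4 values shown sits. Compound 4 also improves on both non-sulfonyl groups, with a 33-fold lower number from compound 2 to compound 4 (1.52 log units; beyond the scatter) and a 12-fold lower number from compound 1 to compound 4 (1.08 log units; beyond the scatter), making it the strongest inhibitor of the four.

As far as these compounds go, whether the gain needs the pyrrolidine ring, or only the replacement of the sulfamoyl hydrogens, stays open. Dimethylamino or piperidin-1-yl on the sulfonyl sulfur would help separate these two readings.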